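Adding an ethoxycarbonyl group to a neutrophil inhibitor

The compounds below may be only part of what the source reports. "The series", "measured", "known", "first", "only" and "open" are said of these compounds alone.

Of the compounds shown here, two have been measured in a functional assay on cells (Neutrophil, Homo sapiens) for inhibition, with a stated time of 10 min; on this read-out lower numbers stand for stronger inhibition and higher numbers for weaker inhibition. Compound 1 `O=C(Nc1ccccc1F)N1c2ccnn2CC1c1ccccc1` gives 5.4 nM in this assay. Compound 2 `O=C(Nc1cccc(F)c1)N1c2ccnn2CC1c1ccccc1` gives 12.1 nM in this assay. Compound 2 therefore has the higher of the two numbers, and the gap from it to compound 1 is given by a 2.2-fold higher number from compound 1 to compound 2 (0.35 log units; beyond the scatter), a change that came from moving a fluorine from one position of a phenyl ring to another.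

Compound 3 `CCOC(=O)c1cnn2c1N(C(=O)Nc1cccc(F)c1)C(c1ccccc1)C2` has not been measured. It differs from compound 2 in one place: ethoxycarbonyl in place of hydrogen on an aromatic carbon. Among the compounds with values here, the only measured step concerns a fluorophenyl group on the amide-type nitrogen and says nothing about adding a group to the shared core, so there is no step among the measured compounds that bears directly on this change.

Within the data shown here, with no precedent for this kind of change, the expected outcome is a step of no clear direction, a 1.0-fold lower number from compound 2 to compound 3 (0.00 log units; within the scatter), and compound 3 is estimated at 12 nM in this assay, within a range of 3 nM to 50 nM.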

Compound 3, half-maximal inhibitory concentration: 9.2 nM
Compound 3: middle estimate off by 1.3-fold (0.12 log units), on the high side; the measured number falls inside the stated range.
By their numbers in this assay, from the lowest: compounds 1, 3 and 2 (each within the scatter of the next, the first and the last beyond it).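

Ethoxycarbonyl in place of hydrogen on this aromatic carbon gives a 1.3-fold lower number from compound 2 to compound 3 (0.12 log units; within the scatter) in this assay, so a group of 5 heavy atoms is accepted here with no difference beyond the usual scatter. Within the data shown here, the only earlier step concerned a fluorine on the phenyl ring, which left the shared core untested; this is the first reading of a change on the core itself, and it shows that at least one substituent on this carbon is compatible with the inhibition seen for compound 2. Nothing measured here explains why compound 2 and compound 3 sit within the scatter of each other.

From the compounds shown here alone, one group on one carbon says little about the position as a whole, and it remains open whether a carboxylic acid, an amine or a simple methyl on the same carbon would also stay within the scatter of compound 2. Also open, going by these compounds, is whether ethoxycarbonyl would give a similar result on compound 1, which carries its fluorine at a different place on the phenyl ring.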